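This account rests on a few compounds, and the source may have more. Where it says the series, first, only, none or still open, it means among the compounds named here.

Measured so far:
compound 1 `CCN1CCN(CC(=O)Nc2ccc(-c3nc(-c4ccccc4)c(-c4ccccc4)n3C)cc2)CC1`, 4.7%
compound 2 `Cn1c(-c2ccc(NC(=O)CN3CCN(Cc4ccccc4)CC3)cc2)nc(-c2ccccc2)c1-c1ccccc1`, 7.2%

In a functional assay on MCF7 cells (Homo sapiens) for cytotoxicity, read by MTT assay, with a stated time of 24 h, tested at 0.64 ug/mL (on this read-out higher numbers stand for a stronger effect at the one concentration tested and lower numbers for a weaker effect), compound 1 gives 4.7% and compound 2 gives 7.2%. Among the measured compounds shown here, the one measured step, a number 2.5 percentage points higher from compound 1 to compound 2 (within the scatter), leaves the two numbers within the scatter of each other, so compound 2 cannot be set apart from compound 1 on this assay.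

Compound 3 `COc1ccc(CN2CCN(CC(=O)Nc3ccc(-c4nc(-c5ccccc5)c(-c5ccccc5)n4C)cc3)CC2)cc1` differs from compound 2 by methoxy in place of hydrogen on an aromatic carbon. For the measured compounds named here, no measured step concerns a methoxy on this ring; the only step available, a number 2.5 percentage points higher from compound 1 to compound 2 (within the scatter), altered the same end of the molecule and stayed within the scatter. A step of about a number 0.2 percentage points lower from compound 2 to compound 3 (within the scatter) is therefore expected, nothing beyond the scatter. Compound 3 is expected to give 7%, in the range 2% to 14%.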

Compound 3, a percentage reported as activity, at one concentration (the size of the read-out at that concentration, not a potency): 1%
Beside the measured number, compound 3's estimate is 6 percentage points above it; measured number below the stated range.
By their numbers in this assay, from the lowest: compounds 3, 1 and 2 (each within the scatter of the next).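

On this assay, methoxy on the aromatic carbon para to a large group, the change from benzyl to 4-methoxybenzyl, gives a number 6.2 percentage points lower from compound 2 to compound 3 (within the scatter), and 4-methoxyphenyl in place of methyl gives a number 3.7 percentage points lower from compound 1 to compound 3 (within the scatter). Methyl, phenyl and 4-methoxyphenyl at this end of the molecule therefore cannot be told apart on this read-out. Nothing available explains these numbers.

On these data alone, whether a hydroxyl or an amine on this ring, or a longer chain in place of benzyl, gives a number beyond the scatter stays open. Also open, as far as these compounds go, is whether the three compounds separate at another concentration.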